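Swapping a Long Alkyl Tail for a Phenyl Ring

This account rests on a few compounds, and the source may have more. Where it says the series, first, only, none or still open, it means among the compounds named here.

Compound 1 `CCCCCCCCOc1ccc2c(Cl)ccnc2c1`: 3240 nM
Compound 2 `CN(C)CCNc1ccnc2cc(OCc3ccccc3)ccc12`: 1620 nM
Compound 3 `CCOc1ccc2c(NCCN(C)C)ccnc2c1`: 3490 nM

Of the compounds shown here, three have been measured in a functional assay on NCI-H1650 cells (Homo sapiens) for cytotoxicity, read by MTT assay, with a stated time of 48 h; a lower number here means a stronger inhibitor, a higher number a weaker inhibitor. Compound 1 gives 3240 nM, which is the second highest of the three numbers; compound 3 sits closest to it, and compound 2 furthest, though both gaps fall within the scatter. Compound 4 `Clc1ccnc2cc(OCCc3ccccc3)ccc12` is not yet measured. It differs from compound 1 in one place: phenyl in place of hexyl on a saturated chain carbon, two bonds along the chain from an oxygen on an aromatic ring.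

Going by the values given here, one measured step bears on this change. From compound 2 to compound 3, methyl in place of phenyl on a saturated chain carbon bound to an oxygen on an aromatic ring gave a 2.2-fold higher number from compound 2 to compound 3 (0.33 log units; beyond the scatter). Read in reverse, putting a phenyl ring where an alkyl group stood went with a lower number. The change from compound 1 to compound 4 is of the same kind, though on a core with a different substituent. A modest move towards a lower number in this assay is therefore expected, roughly a 1.6-fold lower number from compound 1 to compound 4 (0.21 log units; within the scatter). For compound 4 the estimate is 2000 nM, with a range from 800 nM to 5000 nM.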

Compound 4, half-maximal inhibitory concentration: 2300 nM
Estimate against measurement, compound 4: 1.2-fold (0.06 log units) below; the range from low to high includes it.
By their numbers in this assay, from the lowest: compounds 2, 4, 1 and 3 (each within the scatter of the next, the first and the last beyond it).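

In this assay, replacing the open hexyl chain with a phenyl ring of the same heavy-atom count, on a saturated chain carbon two bonds along the chain from an oxygen on an aromatic ring, gives a step within the scatter (a 1.4-fold lower number from compound 1 to compound 4 (0.15 log units; within the scatter)), so compound 1 and compound 4 cannot be told apart. The earlier step from a phenyl to a methyl group lay beyond the scatter (a 2.2-fold higher number from compound 2 to compound 3 (0.33 log units; beyond the scatter)), but it involved a much smaller replacement group and a different place on the chain, whereas this result shows that a ring and a hexyl chain of equal size can stand at this place with no clear change in the number. No measurement is available that would explain this result.

On these data alone, whether an amine or a carboxylic acid in place of phenyl at this same place would shift the number beyond the scatter remains open. So does the effect of a longer chain carrying the phenyl ring.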